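A few compounds are considered here, and "the series" means these few. Any claim that something is new, unique, unknown or untested is made for them only; others in the source may bear on it.

Working notes on the series. Compound 1 `CC(C)(C)Cc1c(-c2cccc(F)c2F)sc(N)c1C(=O)c1ccc(Cl)cc1`, compound 2 `CC(C)(C)Cc1c(/C=C/c2ccc(Cl)cc2)sc(N)c1C(=O)c1ccc(Cl)cc1` and compound 3 `CC(C)(C)Cc1c(-c2ccc(Cl)c(Cl)c2)sc(N)c1C(=O)c1ccc(Cl)cc1` share one core and differ only in the group carried on an aromatic carbon of that core. In an assay on CHO cells for displacement of a labelled ligand from adenosine receptor A1 (Homo sapiens), read by scintillation counting, tested at 10 uM (on this read-out lower numbers stand for less inhibition and higher numbers for more inhibition at the one concentration tested (going by the name of the read-out)), compound 1 gives 1%; in the same assay compound 2 gives 1%, and compound 3 gives 1%. Every pairwise step between them is flat: no change at the digits printed from compound 1 to compound 2 (within the scatter), no change at the digits printed from compound 1 to compound 3 (within the scatter) and no change at the digits printed from compound 2 to compound 3 (within the scatter) all lie within the scatter. Among the measured compounds shown here, compound 3 therefore stands level with compounds 1 and 2 on the numbers available; no compound in this set separates from the others.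

The next compound, compound 4 `Cc1cccc(-c2sc(N)c(C(=O)c3ccc(Cl)cc3)c2CC(C)(C)C)c1`, again keeps the core and alters the same position. Against compound 3 the difference is 3-methylphenyl in place of 3,4-dichlorophenyl on an aromatic carbon.

All three measured steps bear on this change, since each of them exchanged the group on that aromatic carbon for another aryl or aryl-ethenyl group, and none of them moved this assay beyond the scatter. The data give no instance where a change at this position produced a step of any size. The step of a number 1 percentage points higher from compound 3 to compound 4 (within the scatter) is therefore expected to be none beyond the scatter. Compound 4 is estimated at 2%, with a range from -8% to 12%.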

Compound 4, a percentage reported as inhibition, at one concentration (the size of the read-out at that concentration, not a potency): 1%
For compound 4 the middle estimate is 1 percentage points above the measured one; measured number inside the range.
By their numbers in this assay, from the lowest: compounds 1, 2, 3 and 4 (each within the scatter of the next).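

3-methylphenyl is the only group among the four at this position, on the aromatic carbon next to the ring sulfur, that carries no halogen: its 7 heavy atoms are all carbon, where 3,4-dichlorophenyl holds 2 chlorine atoms, yet this assay shows no change at the digits printed from compound 3 to compound 4 (within the scatter). The reading is the same against the other two groups, with no change at the digits printed from compound 2 to compound 4 (within the scatter) and no change at the digits printed from compound 1 to compound 4 (within the scatter), so within these four compounds a halogen on this group makes no difference that can be read, and the series stays close to the bottom of the scale, with compound 4 at 1%. Nothing in hand accounts for this flat reading.

As far as these compounds go, all four groups at this aromatic carbon are aryl or aryl-ethenyl groups, so it remains open whether an amine, a carboxylic acid or a saturated alkyl chain there would give a step beyond the scatter in this assay. Also open, from the compounds shown here alone, is whether a longer chain in place of the neopentyl group, or an amide in place of the amino group, would lift the series from this level.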